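The source may report more compounds than this note shows. Statements on the series, on what has been measured and on what is new or still open speak of the compounds shown alone.

Measured in a functional assay on HeLa cells (Homo sapiens) for inhibition, read by MTT assay; a higher number here means a weaker inhibitor, a lower number a stronger inhibitor:
compound 3 `CCCCCCCCn1cc(/C=C/C(=O)c2ccc(NC(=O)CN3CCN(c4ccc([N+](=O)[O-])cc4)CC3)cc2)nn1` — 30200 nM
compound 1 `COc1ccccc1N1CCN(CC(=O)Nc2ccc(C(=O)/C=C/c3cn(Cc4ccc(Br)cc4)nn3)cc2)CC1` — 26400 nM
compound 2 `CC(C)(C)OC(=O)N1CCN(CC(=O)Nc2ccc(C(=O)/C=C/c3cn(Cc4ccc(Br)cc4)nn3)cc2)CC1` — 18900 nM

Compound 3 has the highest number of the three, but its gaps to compound 1 and to compound 2 are within the scatter, so no order among them can be read. Among the measured compounds shown here, the one measured step, a 1.4-fold lower number from compound 1 to compound 2 (0.15 log units; within the scatter), alters the amine nitrogen in the ring and does not touch the position changed here. Compound 4 `O=C(CN1CCN(c2ccc([N+](=O)[O-])cc2)CC1)Nc1ccc(C(=O)/C=C/c2cn(Cc3ccc(Br)cc3)nn2)cc1` differs from compound 3 by 4-bromophenyl in place of heptyl on a saturated chain carbon bound to an aromatic nitrogen. Compound 1 and compound 2 already carry the 4-bromophenyl on that carbon and give numbers close to that of compound 3, so no step beyond the scatter is expected. For compound 4 in this assay the expected value is 25000 nM (range 11000 nM to 55000 nM), an expected step of a 1.2-fold lower number from compound 3 to compound 4 (0.08 log units; within the scatter).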

Compound 4, half-maximal inhibitory concentration: 26600 nM
The estimate for compound 4 lay 1.1-fold (0.03 log units) below the measured number, and the stated range covers the measured number.
By their numbers in this assay, from the lowest: compounds 2, 1, 4 and 3 (each within the scatter of the next).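

In this assay, the exchange of heptyl for 4-bromophenyl on a saturated chain carbon bound to an aromatic nitrogen now has its own measured step, a 1.1-fold lower number from compound 3 to compound 4 (0.06 log units; within the scatter), so octyl and 4-bromobenzyl are not told apart. On the amine nitrogen in a ring, 4-nitrophenyl is likewise not told apart from the other two groups, with a 1.4-fold higher number from compound 2 to compound 4 (0.15 log units; within the scatter) and a 1.0-fold higher number from compound 1 to compound 4 (0.00 log units; within the scatter). No evidence on the cause is available for this result. The compounds shown leave open whether a longer chain, or a chain ending in a carboxylic acid or an amine, in place of octyl or 4-bromobenzyl would give a step beyond the scatter.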